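The compounds below may be only part of what the source reports. "The series", "measured", "known", "first", "only" and "open" are said of these compounds alone.

Measured in a functional assay on CAKI-1 cells (Homo sapiens) for antiproliferative activity, with a stated time of 48 h; a higher number here means a weaker inhibitor of growth, a lower number a stronger inhibitor of growth:
- compound 1 `Cc1cc(O)c(C2=NN(c3ccc(S(N)(=O)=O)cc3)C(c3ccccc3Cl)C2)cc1Cl` gives 3990 nM
- compound 2 `Cc1cc(O)c(C2=NN(c3ccc(S(N)(=O)=O)cc3)C(/C=C/c3ccccc3)C2)cc1Cl` gives 87700 nM
- compound 3 `COc1ccc(C2CC(c3cc(Cl)c(C)cc3O)=NN2c2ccc(S(N)(=O)=O)cc2)cc1OC` gives 100000 nM

Compound 3 holds the highest of the three numbers in this assay. Its nearest neighbour is compound 2, as a 1.1-fold higher number from compound 2 to compound 3 (0.06 log units; within the scatter) shows; the one furthest from it is compound 1, as a 25-fold higher number from compound 1 to compound 3 (1.40 log units; beyond the scatter) shows. The two large steps in the set, a 22-fold higher number from compound 1 to compound 2 (1.34 log units; beyond the scatter) and a 25-fold higher number from compound 1 to compound 3 (1.40 log units; beyond the scatter), both exchange the whole group on the saturated ring carbon for a different one.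

Compound 4 `COc1ccc(C2CC(c3cc(Cl)c(C)cc3O)=NN2c2ccc(S(N)(=O)=O)cc2)c(OC)c1OC` differs from compound 3 by methoxy in place of hydrogen on an aromatic carbon. Among the measured compounds shown here, no measured step adds a single substituent to a ring that is otherwise kept; every existing step swaps the entire group, and the one step between two substituted groups, a 1.1-fold higher number from compound 2 to compound 3 (0.06 log units; within the scatter), stays within the scatter. For the measured compounds named here, there is therefore no direct precedent for this change, and the expectation rests on compound 3 alone. The step of no change at the digits printed from compound 3 to compound 4 (within the scatter) is expected to be small, with no direction claimed beyond the scatter. Compound 4 is expected to give 100000 nM, within a range from 30000 nM to 300000 nM. Since compound 3 already stands at 100000 nM, the highest number of the three, compound 4 is expected to land near the top of the measured range as well.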

Compound 4, concentration for total growth inhibition: 16900 nM
Compound 4: the middle estimate sits 5.9-fold (0.77 log units) above what was measured; measured number below the stated range.
By their numbers in this assay, from the lowest: compound 1; then compound 4; then compounds 2 and 3 (each within the scatter of the next).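

In this assay, a single methoxy on an otherwise kept ring, placed ortho to a large group and ortho to a methoxy group, gives a step beyond the scatter (a 5.9-fold lower number from compound 3 to compound 4 (0.77 log units; beyond the scatter)), so this aromatic carbon responds to a small addition and not only to exchange of the whole group. The 3,4-dimethoxyphenyl group stayed within the scatter of 2-phenylethenyl, whereas 2,3,4-trimethoxyphenyl separates from it (a 5.2-fold lower number from compound 2 to compound 4 (0.72 log units; beyond the scatter)). The added methoxy still leaves the series short of the 2-chlorophenyl group (a 4.2-fold higher number from compound 1 to compound 4 (0.63 log units; beyond the scatter)), and no measurement here speaks to the reason for either shift.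

Open is whether the methoxy on this carbon carries the step alone, since 2-methoxyphenyl without the other two methoxy groups does not appear among the compounds shown. Also open, on these data alone, is whether a hydroxy group, a fluorine atom or a longer chain such as ethoxy on the same carbon would move the number in the same direction, and by a similar amount.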